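Notes on the amino analogue of compound 3

The source may hold more compounds than are shown below. What is called first, only, known or untested is meant among the compounds shown, and "the series" means these compounds.

- compound 1 `COc1cc(C(=O)c2cn(-c3cccc(C)c3)cc2-c2ccccc2F)cc(OC)c1OC` at 190 nM
- compound 2 `COc1cc(C(=O)c2cn(-c3cccc(N)c3)cc2-c2ccccc2F)cc(OC)c1OC` at 17 nM
- compound 3 `COc1cc(C(=O)c2cn(-c3ccc(F)cc3)cc2-c2ccccc2F)cc(OC)c1OC` at 39 nM

In a functional assay on MCF7 cells (Homo sapiens) for cytotoxicity, read by MTT assay, with a stated time of 96 h (a higher number here means a weaker inhibitor, a lower number a stronger inhibitor), compound 3 (39 nM) holds the middle place of the three, with a 2.3-fold higher number from compound 2 to compound 3 (0.36 log units; beyond the scatter) on one side and a 4.9-fold lower number from compound 1 to compound 3 (0.69 log units; beyond the scatter) on the other.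

Compound 4 `COc1cc(C(=O)c2cn(-c3ccc(F)cc3)cc2-c2ccc(N)cc2)cc(OC)c1OC` is still unmeasured. It has 4-aminophenyl in place of 2-fluorophenyl on an aromatic carbon of a five-membered aromatic ring with 1 nitrogen (4-aminophenyl in place of 2-fluorophenyl on an aromatic carbon).

Among the measured compounds shown here, all three measured compounds carry 2-fluorophenyl, so no measured step varies this place and the evidence is indirect. For the measured compounds named here, the closest precedent is the change to amino from methyl elsewhere in the molecule, which gave an 11-fold lower number from compound 1 to compound 2 (1.05 log units; beyond the scatter) and is the only measured step that brings in an amino group. A modest move towards a lower number is therefore expected, with much uncertainty (a 2.0-fold lower number from compound 3 to compound 4 (0.29 log units; within the scatter)).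

Compound 4 is expected at 20 nM with an estimated range from 5 nM to 80 nM as its likely span.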

Compound 4, half-maximal inhibitory concentration: 12 nM
Compound 4: the middle estimate sits 1.7-fold (0.22 log units) above what was measured, and the stated range covers the measured number.
By their numbers in this assay, from the lowest: compounds 4 and 2 (each within the scatter of the next); then compound 3; then compound 1.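

In this assay, the place two ring bonds from the ring atom that bears a 4-fluorophenyl group now shows its first measured change, with 4-aminophenyl in place of 2-fluorophenyl giving a 3.3-fold lower number from compound 3 to compound 4 (0.51 log units; beyond the scatter), so the 2-fluorophenyl group is not required at this place for a low number. An amino-bearing change now lowers the number at a second place in the molecule, after an 11-fold lower number from compound 1 to compound 2 (1.05 log units; beyond the scatter), although the step here is smaller and also removes the fluorine. Nothing measured on these compounds explains the step.

The compounds shown do not separate the gain of the amino group from the loss of the fluorine, a question that unsubstituted phenyl or 2-aminophenyl at this place would address. Going by these compounds, whether hydroxyl or dimethylamino could stand in for the amino group also remains open.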